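The source may report more compounds than this note shows. Statements on the series, on what has been measured and on what is new or still open speak of the compounds shown alone.

Measured compounds:
compound 1, `CC[C@H]1OC(=O)[C@H](C)[C@@H](O[C@H]2C[C@@](C)(OC)[C@@H](O)[C@H](C)O2)[C@H](C)[C@@H](O[C@@H]2O[C@H](C)C[C@H](N(C)C)[C@H]2O)[C@](C)(O)C[C@@H](C)CN(CCCNC(=O)C2CCC2)[C@H](C)[C@@H](O)[C@]1(C)O`: 2.31
compound 2, `CCCCCCCC(=O)NCCCO[C@H]1[C@H](C)O[C@@H](O[C@H]2[C@H](C)[C@@H](O[C@@H]3O[C@H](C)C[C@H](N(C)C)[C@H]3O)[C@](C)(O)C[C@@H](C)CN(C)[C@H](C)[C@@H](O)[C@](C)(O)[C@@H](CC)OC(=O)[C@@H]2C)C[C@@]1(C)OC`: 4.1
compound 3, `CC[C@H]1OC(=O)[C@H](C)[C@@H](O)[C@H](C)[C@@H](O)[C@](C)(O)C[C@@H](C)CN(C)[C@H](C)[C@@H](O)[C@]1(C)O`: 1.29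

Of the compounds shown here, three have been measured in a physicochemical assay for lipophilicity, read by HPLC, measured as chromatographic lipophilicity, at pH 7.4; on this read-out higher numbers stand for higher lipophilicity and lower numbers for lower lipophilicity. Among them compound 1 stands second highest. Compound 3, the smaller molecule lacking the two sugar parts, gives 1.29, a reading well beyond the usual scatter below that of compound 1. Compound 2, which carries a long open-chain amide on one of the sugar parts, gives 4.1, again beyond the scatter above compound 1. Among the measured compounds shown here, no pair among the three differs in only one place, so no single step can be read from them.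

The unmeasured compound 4, `CCCCC(=O)NCCCN1C[C@H](C)C[C@@](C)(O)[C@H](O[C@@H]2O[C@H](C)C[C@H](N(C)C)[C@H]2O)[C@@H](C)[C@H](O[C@H]2C[C@@](C)(OC)[C@@H](O)[C@H](C)O2)[C@@H](C)C(=O)O[C@H](CC)[C@@](C)(O)[C@H](O)[C@H]1C`, differs from compound 1 in one place: butyl in place of cyclobutyl on a carbonyl carbon. The change sits on a carbonyl carbon whose other neighbours are an amide-type nitrogen. Nothing in the measured set shows this kind of exchange directly. Opening a four-membered ring into a chain of the same carbon count is expected to move the value of compound 1 only a little, upward, with the step from compound 1 to compound 4 estimated at a number 0.29 log units higher from compound 1 to compound 4 (within the scatter), roughly at the edge of the scatter. Compound 4 is therefore expected to give about 2.6 in this assay, within the range 2.2 to 3.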

Compound 4, distribution coefficient: 2.72
For compound 4 the middle estimate is 0.12 log units below the measured one; measured number inside the range.
By their numbers in this assay, from the lowest: compound 3; then compound 1; then compound 4; then compound 2.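

In this assay, among the compounds shown here, the exchange of cyclobutyl for butyl on a carbonyl carbon whose other neighbours are an amide-type nitrogen gives the first single-place step of the set, with the reading coming out a number 0.41 log units higher from compound 1 to compound 4 (beyond the scatter). The leaving and entering groups have the same count of heavy atoms, all carbon, and differ in the four-membered ring, so the exchange of that ring for an open chain at this position is enough to shift the reading past the usual scatter. Nothing at hand gives a reason for this step.

On these data alone, it remains open whether a longer chain, a branched chain such as isobutyl, or a larger ring such as cyclopentyl on this carbonyl carbon would shift the reading in the same direction. As far as these compounds go, how an amine or a carboxylic acid at the end of the butyl chain would read also stays unknown.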